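The source may report more compounds than this note shows. Statements on the series, on what has been measured and on what is new or still open speak of the compounds shown alone.

Compound 1 `Clc1ncc2sccc2n1` and compound 2 `Clc1nc(-n2cncn2)c2sccc2n1` share the same core, the second carrying a 1H-1,2,4-triazol-1-yl group. In a functional assay on CCRF-CEM cells (Homo sapiens) for cytotoxicity, read by cell counting, with a stated time of 72 h (on this read-out higher numbers stand for weaker inhibition and lower numbers for stronger inhibition), compound 1 gives only a limit of the assay, > 250000 nM. In this assay compound 2 likewise gives only a limit, > 250000 nM. The change a step that the two limits leave unreadable from compound 1 to compound 2 stays unreadable because both values sit at the limit of > 250000 nM in this assay, at which 2 of the 2 values shown sit. Compound 3 `Clc1nc(-n2cncn2)c2scc(Br)c2n1` differs from compound 2 by bromo in place of hydrogen on an aromatic carbon. Within the data shown here, no measured step bears on this change, and compound 2 stands at the limit, so no direction can be foreseen. The step of a number no higher from compound 2 to compound 3 (the limit leaves the size open) is expected to stay within the scatter. Compound 3 is expected to give about 250000 nM in this assay, between 60000 nM and 500000 nM.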

Compound 3, half-maximal inhibitory concentration: 84000 nM
Estimate against measurement, compound 3: 3.0-fold (0.47 log units) above, and the stated range covers the measured number.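

In this assay, among these compounds, bromo in place of hydrogen on an aromatic carbon gives an at least 2.9-fold lower number from compound 2 to compound 3 (0.47 log units; beyond the scatter), the first step here that can be read in a direction. It shows that this carbon of the five-membered ring, two ring bonds from the ring sulfur, is a place where one added atom can lower the number. How far it lowers it stays unknown, since compound 2 gives only a limit: the limit of > 250000 nM in this assay, at which 2 of the 3 values shown sit.

As far as these compounds go, whether chloro, methyl or an amine on this carbon would act as bromo does remains open. So does whether the bromo step depends on the 1H-1,2,4-triazol-1-yl group.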